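The source may report more compounds than this note shows. Statements on the series, on what has been measured and on what is new or still open speak of the compounds shown alone.

Measured so far in a functional assay on the whole organism (strain Swiss albino) with Mus musculus as the target, in the maximal electroshock model, with a stated time of 4 h; a lower number here means that less compound is needed, a higher number that more compound is needed for the effect:
- compound 1 `C/C(=N/NC(=O)Nc1nnc(COc2ccc3ccccc3c2)o1)c1ccc(N)cc1` gives 300 mg/kg
- compound 2 `C/C(=N/NC(=O)Nc1nnc(COc2ccc3ccccc3c2)o1)c1ccc(O)cc1` gives 300 mg/kg
- compound 3 `O=C(N/N=C\c1ccc(O)cc1)Nc1nnc(COc2ccc3ccccc3c2)o1` gives 300 mg/kg

All three share the same core and differ only at the hydrazone end. Compound 3 stands level with compound 1 and compound 2: the step of no change at the digits printed from compound 1 to compound 3 (within the scatter) and the step of no change at the digits printed from compound 2 to compound 3 (within the scatter) both sit within the scatter, as does the step of no change at the digits printed from compound 1 to compound 2 (within the scatter) between the two ketone-derived analogues. For the measured compounds named here, nothing among the measured compounds moves this assay at the digits recorded.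

Compound 4 `CN(C)c1ccc(/C=N\NC(=O)Nc2nnc(COc3ccc4ccccc4c3)o2)cc1` is not yet measured. It differs from compound 3 by dimethylamino in place of hydroxy on an aromatic carbon. Going by the values given here, the one measured step that touches the same position is the step of no change at the digits printed from compound 1 to compound 2 (within the scatter), where an exchange of one small polar group for another at that aromatic carbon left the read-out where it was. The other two steps, no change at the digits printed from compound 1 to compound 3 (within the scatter) and no change at the digits printed from compound 2 to compound 3 (within the scatter), change the hydrazone side more broadly and also stay flat. No step beyond the scatter is therefore expected in this assay for compound 4; the estimated step is no change at the digits printed from compound 3 to compound 4 (within the scatter), in no particular direction.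

For compound 4 the expected value in this assay is 300 mg/kg, with a range from 150 mg/kg to 600 mg/kg.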

Compound 4, minimum effective dose: 300 mg/kg
The estimate for compound 4 equals the measured number at the digits printed; low and high end bracket the measured number.
By their numbers in this assay, from the lowest: compounds 1, 2, 3 and 4 (each within the scatter of the next).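

In this assay the new step reads no change at the digits printed from compound 3 to compound 4 (within the scatter) and shows that this aromatic carbon tolerates more than an exchange of amino and hydroxy: dimethylamino, with 0 hydrogen-bond donors, takes the place of hydroxy, with 1 hydrogen-bond donor, and the read-out stays within the scatter. The earlier step at this place, no change at the digits printed from compound 1 to compound 2 (within the scatter) in the ketone-derived pair, covered only an exchange of amino and hydroxy, so the flat reading now extends to a larger group without a hydrogen-bond donor and to the series without the extra methyl on the hydrazone carbon. No measurement here gives a reason for this flat reading in the series.

The compounds shown leave open whether a carboxylic acid, a chlorine atom or a longer chain such as butoxy on this same aromatic carbon would move the read-out in this assay beyond the scatter. They also leave open whether any change at the hydrazone end can shift this read-out, since every step shown so far stays within the scatter.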